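Acylglycine anilides: a nitrogen returned to the acyl chain

This account rests on a few compounds, and the source may have more. Where it says the series, first, only, none or still open, it means among the compounds named here.

Compounds measured in a functional assay on the whole organism with Mus musculus as the target, in the rotarod test; a higher number here means that more compound is needed for the effect, a lower number that less compound is needed:
compound 1 `CN(C(=O)CNC(=O)CN)c1ccc(Cl)cc1C(=O)c1ccccc1Cl`: 27.7 mg/kg
compound 2 `CC(=O)NCC(=O)Nc1ccc(Cl)cc1C(=O)c1ccccc1`: a limit of the assay, > 100 mg/kg
compound 3 `CCCCC(=O)NCC(=O)N(C)c1ccc(Cl)cc1C(=O)c1ccccc1Cl`: 90 mg/kg
Not yet measured: compound 4 `CCN(CC)CC(=O)NCC(=O)N(C)c1ccc(Cl)cc1C(=O)c1ccccc1Cl`.

Compound 3 holds the highest of the two numbers; the nearest is compound 1, with the lower number. The value for compound 2 is a limit of the assay and no number. Among the measured compounds shown here, the one measured step that bears on the present change is a 3.2-fold higher number from compound 1 to compound 3 (0.51 log units; beyond the scatter), a modest rise in dose when the nitrogen on that chain carbon was given up for a carbon chain. Compound 4 differs from compound 3 by diethylamino in place of propyl on a saturated chain carbon bound to a carbonyl carbon, which brings a nitrogen back to that carbon, as in compound 1, though now carrying two ethyl groups rather than hydrogens. A partial reversal of the step from compound 1 to compound 3 is therefore expected in this assay: a lower number for compound 4, of modest size, most likely short of a full return to compound 1. The expected step is a 2.0-fold lower number from compound 3 to compound 4 (0.30 log units; within the scatter). Compound 4 is expected at 45 mg/kg, with a range from 18 mg/kg to 110 mg/kg.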

Compound 4, dose for half-maximal effect: 34 mg/kg
For compound 4 the middle estimate is 1.3-fold (0.12 log units) above the measured one, and the stated range covers the measured number.
By their numbers in this assay, from the lowest: compounds 1 and 4 (each within the scatter of the next); then compound 3. At a limit, above all of these: compound 2.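

In this assay, the return of a nitrogen to the saturated chain carbon bound to a carbonyl carbon gives a 2.6-fold lower number from compound 3 to compound 4 (0.42 log units; beyond the scatter) and so goes with a lower number even when that nitrogen carries two ethyl groups. The earlier compounds shown here showed only the loss of amino at this place; the new comparison gives a 1.2-fold higher number from compound 1 to compound 4 (0.09 log units; within the scatter), so amino and diethylamino cannot be told apart here. No measurement shown gives a cause for either step.

Diethylamino also brings more carbon than propyl, so the compounds shown do not separate the effect of the nitrogen from that of the added carbons; a branched pentyl chain at this place would address this. Also open, on these data alone, is how a cyclic amine such as piperidine or a carboxylic acid would read at this place.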